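Swapping the pendant benzyl on a shared sulfonamide core

A few compounds are considered here, and "the series" means these few. Any claim that something is new, unique, unknown or untested is made for them only; others in the source may bear on it.

Measured so far:
compound 1, `CCc1ccccc1N(Cc1nnc(Cc2ccccc2)o1)S(=O)(=O)c1ccc(C)cc1`: 1000 nM
compound 2, `CCOc1ccc(Cc2nnc(CN(c3cccc(Cl)c3Cl)S(=O)(=O)c3ccc(C)cc3)o2)cc1`: 6.31 nM
compound 3, `Cc1ccc(S(=O)(=O)N(Cc2nnc(Cc3ccc(N(C)C)cc3)o2)c2cccc(Cl)c2C)cc1`: 12.6 nM

Of the compounds shown here, three on the same core have been measured in an assay on CHO cells for displacement of a labelled ligand from prostaglandin E2 receptor EP1 subtype (Homo sapiens); on this read-out higher numbers stand for weaker inhibition and lower numbers for stronger inhibition. Compound 1 gives 1000 nM and stands far apart from the other two. Compound 2 gives 6.31 nM and compound 3 gives 12.6 nM; these two values lie within the usual scatter of each other, so no order between them can be claimed. Compound 3 thus sits with compound 2 at the strong end of the set, and well away from compound 1.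

Compound 4, `Cc1ccc(S(=O)(=O)N(Cc2nnc(Cc3ccc(Cl)cc3Cl)o2)c2cccc(Cl)c2C)cc1`, has not yet been measured. It differs from compound 3 in one place: 2,4-dichlorophenyl in place of 4-(dimethylamino)phenyl on a saturated chain carbon bound to an aromatic carbon. Going by the values given here, the data hold no step in which the group on this saturated chain carbon is changed on its own, so no measured step guides the expectation directly. Compound 2 and compound 3 carry different groups there and still sit within the scatter of each other, which suggests that this position tolerates change. The expected step from compound 3 to compound 4 is therefore small, a 2.0-fold higher number from compound 3 to compound 4 (0.30 log units; within the scatter), leaning toward a somewhat weaker result. For compound 4 the estimate is 25 nM, with a range from 6 nM to 100 nM.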

Compound 4, half-maximal inhibitory concentration: 63.1 nM
Beside the measured number, compound 4's estimate is 2.5-fold (0.40 log units) below it; measured number inside the range.
By their numbers in this assay, from the lowest: compounds 2 and 3 (each within the scatter of the next); then compound 4; then compound 1.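

In this assay, going by these compounds alone, replacing 4-(dimethylamino)phenyl with 2,4-dichlorophenyl on a saturated chain carbon bound to an aromatic carbon gives the first reading of a change at this place on its own: a 5.0-fold higher number from compound 3 to compound 4 (0.70 log units; beyond the scatter). Compounds 2 and 3 also carry different groups there, but they differ elsewhere as well, so their closeness could not show what this place alone contributes; this modest step shows that the read-out does respond to the group held here, even though compound 4 at 63.1 nM remains far from the weak compound 1 at 1000 nM, a compound that differs from it in more than one place. The data on hand offer no measurement that accounts for the step.

The compounds shown leave open whether the step goes with the loss of the dimethylamino group or with the arrival of the two chlorines, as both change together here. As far as these compounds go, a plain benzyl, a benzyl with a single chlorine, or a benzyl bearing a carboxylic acid on the core of compound 3 would begin to separate these, and whether the same step holds with other groups on the sulfonamide nitrogen also remains open.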